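Formyl to acetyl on the amide of the shared core

This account rests on a few compounds, and the source may have more. Where it says the series, first, only, none or still open, it means among the compounds named here.

The series shares the core of compound 1 `CO[C@@H]1/C(=N/O)C[C@H]2O[C@]1(C)n1c3ccccc3c3c4c(c5c6ccccc6n2c5c31)C(=O)NC4`, which in an assay on isolated protein for inhibition of protein kinase C theta type (Homo sapiens), read by HTRF (a lower number here means a stronger inhibitor, a higher number a weaker inhibitor), gives > 2500 nM; this is a limit of the assay, not a number. Compound 2 `CO[C@@H]1[C@H](NC(=O)C(=O)c2c[nH]c3ccccc23)C[C@H]2O[C@]1(C)n1c3ccccc3c3c4c(c5c6ccccc6n2c5c31)C(=O)NC4` carries an indolylglyoxylamide and in this assay gives 1790 nM. Compound 3 `CO[C@@H]1[C@H](NC=O)C[C@H]2O[C@]1(C)n1c3ccccc3c3c4c(c5c6ccccc6n2c5c31)C(=O)NC4` bears a formylamino group; in this assay compound 3 gives > 2500 nM, again a limit. Going by these compounds, the step of an at least 1.3-fold higher number from compound 2 to compound 3 (0.14 log units; that floor lies within the scatter) is bounded only by the limit of > 2500 nM in this assay, at which 2 of the 3 values shown sit, so its true size stays open. Compound 4 `CO[C@@H]1[C@H](NC(C)=O)C[C@H]2O[C@]1(C)n1c3ccccc3c3c4c(c5c6ccccc6n2c5c31)C(=O)NC4` differs from compound 3 by methyl in place of hydrogen on a carbonyl carbon. Among the compounds with values here, no measured step covers this change; the single step into compound 3, from compound 2, offers no direction for a methyl in place of hydrogen on the carbonyl carbon. For compound 4 the expected change is a step that the limit leaves unreadable from compound 3 to compound 4, not beyond the scatter, and a limit is again the most probable report. Compound 4 is estimated at 3200 nM, within 1500 nM to 9000 nM.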

Compound 4, half-maximal inhibitory concentration: 38 nM
For compound 4 the middle estimate is 84-fold (1.93 log units) above the measured one; the whole stated range lies above it.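

In this assay, the amide on the shared core proves highly sensitive to the group on its carbonyl carbon: methyl in place of hydrogen gives an at least 65-fold lower number from compound 3 to compound 4 (1.81 log units; beyond the scatter). Acetyl also outperforms the indolylglyoxylamide, with a 47-fold lower number from compound 2 to compound 4 (1.67 log units; beyond the scatter), so among these three amides potency does not rise or fall steadily with the size of the group, and compound 4 stands apart from compound 2 and compound 3. The step from the formylamino group to the acetamido group is a floor and not a full size: the limit of > 2500 nM in this assay, at which 2 of the 4 values shown sit.

Going by these compounds, whether the gain persists beyond methyl remains open, as a propionyl group or a longer chain on the same carbonyl carbon would show. The compounds shown also leave open how the free amine compares with these amides, and they give no reason for the jump.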